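Side-chain exchange from compound 3 to compound 4

The source may report more compounds than this note shows. Statements on the series, on what has been measured and on what is new or still open speak of the compounds shown alone.

Measured in an ADME assay on microsomes from liver (Mus musculus) for metabolic stability, read by LC-MS, using NADPH, with stated times of 10 min and 30 min, tested at 1 uM; a lower number here means slower removal, a higher number faster removal of the compound:
Compound 1 `COC(=O)C1=C(CN2CCC(O)CC2)NC(c2nccs2)=NC1(C)c1ccc(F)cc1` gives 81 mL/min/kg
Compound 2 `COC(=O)C1=C(Cn2ccnc2)NC(c2nccs2)=NC1(C)c1ccc(F)cc1` gives 69 mL/min/kg
Compound 3 `COC(=O)C1=C(COC2CCOC2)NC(c2nccs2)=NC1(C)c1ccc(F)cc1` gives 79 mL/min/kg

Compound 3 (79 mL/min/kg) cannot be separated from compound 1 (81 mL/min/kg) or from compound 2 (69 mL/min/kg) in this assay on these numbers. Going by the values given here, compound 4 `COC(=O)C1=C(COC(C(=O)O)C(F)(F)F)NC(c2nccs2)=NC1(C)c1ccc(F)cc1` carries 1-carboxy-2,2,2-trifluoroethyl in place of oxolan-3-yl on an oxygen on a saturated carbon and no measured compound carries this group.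

The closest evidence is three exchanges on the saturated chain carbon: a 1.2-fold lower number from compound 1 to compound 2 (0.07 log units; within the scatter) and a 1.0-fold lower number from compound 1 to compound 3 (0.01 log units; within the scatter) and a 1.1-fold higher number from compound 2 to compound 3 (0.06 log units; within the scatter) are the whole of it. All three stay within the scatter, although the groups exchanged differ widely. Among the compounds with values here, they offer no measured precedent for a large step, but none of them tests the entering group, so the range has to stay wide. The expected change is a 1.4-fold lower number from compound 3 to compound 4 (0.16 log units; within the scatter) in this assay and so no step beyond the scatter is expected. Within the data shown here, the slight lean toward a lower number is a judgement on the new group alone, with no measured step behind it. Compound 4 is estimated at 55 mL/min/kg with an expected range of 20 mL/min/kg to 85 mL/min/kg as the working figure.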

Compound 4, clearance in the Mus musculus assay: 24 mL/min/kg
Estimate against measurement, compound 4: 2.3-fold (0.36 log units) above; the range from low to high includes it.
By their numbers in the Mus musculus assay, from the lowest: compound 4; then compounds 2, 3 and 1 (each within the scatter of the next).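

In the Mus musculus assay, the side-chain position had shown no step beyond the scatter, even though the groups exchanged differed widely. Going by these compounds alone, compound 4 is the first compound to separate from the others, with a 3.3-fold lower number from compound 3 to compound 4 (0.52 log units; beyond the scatter), a 2.9-fold lower number from compound 2 to compound 4 (0.46 log units; beyond the scatter) and a 3.4-fold lower number from compound 1 to compound 4 (0.53 log units; beyond the scatter), so exchanges at this position can move clearance beyond the scatter, though only modestly here. In a physicochemical assay for solubility, read by HPLC, in phosphate buffer, at pH 6.5 (on this read-out lower numbers stand for lower solubility and higher numbers for higher solubility), 1-carboxy-2,2,2-trifluoroethyl in place of oxolan-3-yl on an oxygen on a saturated carbon also separates the pair, by a large step: the measured solubility of compound 3, 30 ug/mL, and of compound 4, > 649 ug/mL, an at least 21-fold higher number (1.33 log units; beyond the scatter). In the physicochemical assay compound 3 gives 30 ug/mL as a measured number. In the physicochemical assay compound 4 gives > 649 ug/mL which is a limit and not a number: the limit of > 649 ug/mL in the physicochemical assay, at which 1 of the 2 values shown sits.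

The entering group brings the carboxy and trifluoromethyl parts together, so the compounds shown cannot assign either the clearance step or the solubility step to one part alone. A plain 2,2,2-trifluoroethyl group or a carboxymethyl group on the same oxygen would separate the two parts, and an amine-linked carboxylic acid on the saturated chain carbon would show whether the oxygen matters.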